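Removing the acetal from one drawn configuration

The compounds below may be only part of what the source reports. "The series", "measured", "known", "first", "only" and "open" are said of these compounds alone.

Compound 3 `CC1(C)OC[C@@H](Cn2cc(Cn3c4c(c5ccccc53)C(=O)c3c[n+]([O-])c5ccccc5c3C4=O)nn2)O1` carries a 2,2-dimethyl-1,3-dioxolan-4-yl group. In a functional assay on MDA-MB-231 cells (Homo sapiens) for cytotoxicity, read by MTT assay, with a stated time of 72 h (a lower number here means a stronger inhibitor, a higher number a weaker inhibitor), compound 3 reaches only the limit > 1000 nM, so its place among the measured compounds cannot be read. Compound 2 `CC1(C)OC[C@H](Cn2cc(Cn3c4c(c5ccccc53)C(=O)c3c[n+]([O-])c5ccccc5c3C4=O)nn2)O1`, which differs only in the drawn configuration, gives 530 nM, and the step of an at least 1.8-fold higher number from compound 2 to compound 3 (0.27 log units; that floor lies within the scatter) stays inside the scatter. Compound 1 `O=C1c2c[n+]([O-])c3ccccc3c2C(=O)c2c1c1ccccc1n2Cc1cn(CC(O)CO)nn1`, carrying the open 1,2-dihydroxyethyl group with no drawn configuration, gives 1290 nM. Compound 4 `O=C1c2c[n+]([O-])c3ccccc3c2C(=O)c2c1c1ccccc1n2Cc1cn(C[C@@H](O)CO)nn1` is reached through the change (1,2-dihydroxyethyl in place of 2,2-dimethyl-1,3-dioxolan-4-yl on a saturated chain carbon bound to an aromatic nitrogen). The step of a 2.4-fold lower number from compound 1 to compound 2 (0.39 log units; beyond the scatter) bears on this in reverse, and it was modest, so a modest rise in this assay, or none beyond the scatter, is expected. Compound 4 is therefore estimated at 1500 nM, within 700 nM to 3500 nM. The expected step is a step that the limit leaves unreadable from compound 3 to compound 4.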

Compound 4, half-maximal inhibitory concentration: 670 nM
The estimate for compound 4 lay 2.2-fold (0.35 log units) above the measured number; the measured number lies below the stated range.
By their numbers in this assay, from the lowest: compounds 2, 4 and 1 (each within the scatter of the next, the first and the last beyond it).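

In this assay, the open group holds up as well as the acetal at this place: a 1.3-fold higher number from compound 2 to compound 4 (0.10 log units; within the scatter), which lies within the scatter, so this swap of 2,2-dimethyl-1,3-dioxolan-4-yl for 1,2-dihydroxyethyl shows no readable cost. Drawing a defined configuration shows no readable gain either, with a 1.9-fold lower number from compound 1 to compound 4 (0.28 log units; within the scatter), also within the scatter. Compound 3 has only a limit, so an at least 1.4-fold lower number from compound 3 to compound 4 (0.17 log units; that floor lies within the scatter) is just a floor, and it stays within the scatter too. Still open, as far as these compounds go, are how the opposite drawn configuration of 1,2-dihydroxyethyl compares and whether an amine, a carboxylic acid or a longer chain at this place would shift the number beyond the scatter.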